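Growth inhibition of a cinnamate ester pair and a third

A few compounds are considered here, and "the series" means these few. Any claim that something is new, unique, unknown or untested is made for them only; others in the source may bear on it.

Measured compounds:
compound 1, `CC(C)=CCCC(C)CCOC(=O)/C=C/c1ccc(C(C)C)cc1`, 0%
compound 2, `O=C(/C=C/c1ccc(Cl)cc1)OCCOc1ccccc1`, 0%

Compound 1 carries an isopropyl on its aromatic ring and a branched alkenyl ester chain. In a functional assay on the whole organism for inhibition, with Brassica rapa subsp. chinensis as the target, with a stated time of 3 days, tested at 100 ppm (a lower number here means less inhibition of growth, a higher number more inhibition of growth at the concentration tested), compound 1 gives 0%. Compound 2 keeps the same trans-alkene ester but carries a chloro on the ring and a phenoxyethyl ester chain; in this assay compound 2 gives 0%. On the numbers shown, compound 2 stands level with compound 1 at the digits printed, with no change beyond the usual scatter.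

Compound 3, `CC(C)c1ccc(/C=C/C(=O)OCCOc2ccccc2)cc1`, has not yet been measured. It differs from compound 2 by the change (isopropyl in place of chloro on an aromatic carbon), that is, isopropyl in place of chloro on an aromatic carbon, para to a large group. Among the compounds with values here, no step between two measured compounds is available for this change. Since both compound 1 and compound 2 sit at the same level, no step beyond the scatter is expected in this assay, in either direction. Compound 3 is therefore expected to give about 0%, within 0% to 15%, which means an expected step of no change at the digits printed from compound 2 to compound 3 (within the scatter).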

Compound 3, percent growth inhibition at one concentration: 0%
Beside the measured number, compound 3's estimate shows no gap at the digits printed, within the range that was stated.
By their numbers in this assay, from the lowest: compounds 1, 2 and 3 (each within the scatter of the next).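

In this assay the exchange of chloro for isopropyl on an aromatic carbon, para to a large group, gives no change at the digits printed from compound 2 to compound 3 (within the scatter) and so adds a ring change to the picture: with the phenoxyethyl ester chain held constant, neither ring group gives a reading above zero. Compound 3 also links the two earlier compounds, which differ in both the ring group and the ester chain, and the change of phenoxy in place of 1,5-dimethylhex-4-en-1-yl on the saturated chain gives no change at the digits printed from compound 1 to compound 3 (within the scatter) with the isopropyl held constant. Within the data shown here, since compound 3 gives 0% like the other two, these steps show only that neither single change produces measurable growth inhibition under these conditions, and they cannot rank the groups, while no supporting measurement offers an explanation for the result.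

On these data alone, what an amine or a carboxylic acid would do at this ring position remains open, as does the effect of a longer chain on the ester. Also open, as far as these compounds go, is whether any ring group or ester chain on this shared core can lift growth inhibition above zero in this assay at all.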